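This account rests on a few compounds, and the source may have more. Where it says the series, first, only, none or still open, it means among the compounds named here.

Measured in a functional assay on DU-145 cells (Homo sapiens) for inhibition, read by trypan blue exclusion, with a stated time of 96 h; a higher number here means a weaker inhibitor of growth, a lower number a stronger inhibitor of growth:
- Compound 1 `Cc1ccc(S(=O)(=O)/C(=C/c2sccc2C)C(=O)c2ccc(Br)cc2)cc1`: 25000 nM
- Compound 2 `O=C(/C(=C\c1ccc(F)cc1F)S(=O)(=O)c1ccc(Br)cc1)c1ccc(Br)cc1`: 7500 nM

Compound 2 has the lower of the two numbers, and the gap up to compound 1 lies beyond the usual scatter. These two compounds differ in more than one place, so their gap cannot be tied to any single change.

Compound 3 `Cc1ccc(S(=O)(=O)/C(=C/c2ccc(F)cc2F)C(=O)c2ccc(Br)cc2)cc1` follows from compound 2 with methyl in place of bromo on an aromatic carbon, para to a large group: methyl in place of bromo on an aromatic carbon. Among the compounds with values here, no measured pair shows this change alone. Compound 1 also carries the 4-methylphenyl and gives 25000 nM, which is only weak guidance, as it differs from compound 3 elsewhere. A small shift toward weaker growth inhibition in this assay is therefore expected, barely beyond the scatter if at all. The expected 1.3-fold higher number from compound 2 to compound 3 (0.12 log units; within the scatter) is modest. Compound 3 is estimated at 10000 nM, with an expected range of 4000 nM to 25000 nM.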

Compound 3, concentration for 50% growth inhibition: > 100000 nM
Compound 3 gave a limit, no number; the forecaster's own chance of this, stated with the estimate: 10%; middle value at least 10-fold (1.00 log units) from the limit.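

In this assay, compound 3 stands at a limit of the assay and not at a number: the limit of > 100000 nM in this assay, at which 1 of the 3 values shown sits. Methyl in place of bromo on this aromatic carbon, para to a large group, gives an at least 13-fold higher number from compound 2 to compound 3 (1.12 log units; beyond the scatter), so this one place carries a large step, which the earlier pair, differing in more than one place, could not isolate. With the 4-methylphenyl kept, 2,4-difluorophenyl in place of 3-methylthiophen-2-yl gives an at least 4.0-fold higher number from compound 1 to compound 3 (0.60 log units; beyond the scatter), so the 2,4-difluorophenyl does not by itself secure growth inhibition in this assay.

As far as these compounds go, how far compound 3 lies past its limit stays open, and with it the full size of both steps. Also open, from the compounds shown here alone, is how other groups at this place, such as chloro, methoxy or an amine, would compare with bromo and methyl.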